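The source may report more compounds than this note shows. Statements on the series, on what has been measured and on what is new or still open speak of the compounds shown alone.

Measured compounds:
Compound 1 `Cn1cc(-c2n[nH]c3cc(N)ccc23)cn1` — in an assay on isolated protein for inhibition of tyrosine-protein kinase receptor UFO (Homo sapiens), with a stated time of 1.5 h (on this read-out higher numbers stand for weaker inhibition and lower numbers for stronger inhibition), compound 1 gives 28800 nM
Compound 2 `Cn1cc(-c2n[nH]c3cc(Nc4ccccc4)ccc23)cn1` — in this assay compound 2 gives 219000 nM
Compound 3 `Cn1cc(-c2n[nH]c3cc(Br)ccc23)cn1` — in this assay compound 3 gives 950 nM

Compound 3 carries the lowest number of the three and stands apart from both others: a 30-fold lower number from compound 1 to compound 3 (1.48 log units; beyond the scatter) and a 230-fold lower number from compound 2 to compound 3 (2.36 log units; beyond the scatter), each beyond the scatter. Both of these steps change only the substituent at the carbon that is varied in this series, so that carbon is plainly a sensitive position.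

Compound 4 `Cn1cc(-c2n[nH]c3cc(-c4ccccc4)ccc23)cn1` differs from compound 3 by phenyl in place of bromo on an aromatic carbon. Going by the values given here, no measured step exchanges bromo for a carbon-linked ring at this carbon, so there is no direct precedent. Among the compounds with values here, the only step that introduces a phenyl, a 7.6-fold higher number from compound 1 to compound 2 (0.88 log units; beyond the scatter), places it on a nitrogen and weakens inhibition by a modest margin; whether a phenyl bound directly to the aromatic carbon behaves the same is unknown. A moderate move toward weaker inhibition in this assay is therefore expected, with wide uncertainty, as a 3.2-fold higher number from compound 3 to compound 4 (0.50 log units; beyond the scatter). The estimate for compound 4 is 3000 nM, with a range from 500 nM to 20000 nM.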

Compound 4, half-maximal inhibitory concentration: 12300 nM
Compound 4: the middle estimate sits 4.1-fold (0.61 log units) below what was measured; the range from low to high includes it.
By their numbers in this assay, from the lowest: compound 3; then compound 4; then compound 1; then compound 2.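

In this assay phenyl bound directly to this aromatic carbon falls well short of bromo (a 13-fold higher number from compound 3 to compound 4 (1.11 log units; beyond the scatter)), yet it outperforms the nitrogen-linked anilino (an 18-fold lower number from compound 2 to compound 4 (1.25 log units; beyond the scatter)), so the linking atom matters as well as the ring. Phenyl also improves modestly on amino (a 2.3-fold lower number from compound 1 to compound 4 (0.37 log units; beyond the scatter)), which shows that this carbon can carry a ring without the loss seen with anilino, and the two ring-bearing groups fall on either side of amino, so the presence of a ring does not set the order. No measurement on hand accounts for this order.

Still open, going by these compounds, is whether another halogen such as chloro or iodo can match or pass bromo. Equally open, on these data alone, is whether a phenyl carrying an amine or a carboxylic acid, or a small carbon group such as methyl, recovers the level of compound 3.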